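A few compounds are considered here, and "the series" means these few. Any claim that something is new, unique, unknown or untested is made for them only; others in the source may bear on it.

Among the compounds with values here, in a toxicity assay on J774.A1 cells (Mus musculus) for cytotoxicity, read by SYBR Green assay, with a stated time of 1 h (on this read-out higher numbers stand for an effect only at larger amounts of compound and lower numbers for an effect already at smaller amounts), compound 1 `CN(C)c1ccc2cc(-c3ccccc3)c(N)nc2c1` gives 4900 nM and compound 2 `CN(C)c1ccc2cc(-c3ccccc3F)c(N)nc2c1` gives 1600 nM, so compound 2 holds the lower of the two numbers so far. Compound 3 `CN(C)c1ccc2cc(-c3ccccc3Cl)c(N)nc2c1` keeps the shared core and carries chloro in place of fluoro on an aromatic carbon, ortho to a large group: chloro in place of fluoro on an aromatic carbon. Within the data shown here, only one measured step bears on this change, and only indirectly. That step, a 3.1-fold lower number from compound 1 to compound 2 (0.49 log units; beyond the scatter), put fluoro in place of hydrogen on an aromatic carbon and was modest. Among the measured compounds shown here, no measured compound yet carries chloro, so the data give no direct precedent. A small further drop seems the likeliest outcome, and the expected change, a 1.2-fold lower number from compound 2 to compound 3 (0.09 log units; within the scatter), is estimated to stay within the scatter. In this assay, the estimate for compound 3 is 1300 nM, with an expected range of 550 nM to 3000 nM.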

Compound 3, half-maximal effective concentration: 2400 nM
Estimate against measurement, compound 3: 1.8-fold (0.27 log units) below; the range from low to high includes it.
By their numbers in this assay, from the lowest: compounds 2 and 3 (each within the scatter of the next); then compound 1.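

In this assay, a 1.5-fold higher number from compound 2 to compound 3 (0.18 log units; within the scatter) stays within the scatter, so at this position, ortho to a large group, chloro and fluoro cannot be told apart. Chloro also has its own step from hydrogen, a 2.0-fold lower number from compound 1 to compound 3 (0.31 log units; beyond the scatter), which lies beyond the scatter, so the drop from compound 1 is no longer seen with fluoro alone but with both of these groups. No measurement at hand explains why chloro and fluoro read alike here.

On these data alone, whether bromo, methoxy, an amine or a carboxylic acid at this position would give a number close to those of compound 2 and compound 3 stays open. Also open, as far as these compounds go, is whether chloro and fluoro would still read alike on cells other than these.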